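From Cyclohexyl to Vinyl: Expected Tolerance of Compound 3

The compounds below may be only part of what the source reports. "The series", "measured", "known", "first", "only" and "open" are said of these compounds alone.

Measured so far:
- compound 1, `CCC1(Cc2ccccc2)OS(=O)(=O)C=C1NCc1ccccc1`, gives 92000 nM in an ADME assay on HEL cells (Homo sapiens) for cytotoxicity, with a stated time of 3 days; a higher number here means that more compound is tolerated, a lower number that less compound is tolerated.
- compound 2, `CCC1(Cc2ccccc2)OS(=O)(=O)C=C1OCC1CCCCC1`, reaches the assay limit of > 200000 nM in this assay.

Compound 2 is therefore not placed at a number; its value is only a limit, as recorded in the limit of > 200000 nM in this assay, at which 1 of the 2 values shown sits. Among the compounds with values here, the single measured step, an at least 2.1-fold higher number from compound 1 to compound 2 (0.33 log units; beyond the scatter), shows that the move from compound 1 to the limit is at least modest.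

Compound 3, `C=CCOC1=CS(=O)(=O)OC1(CC)Cc1ccccc1`, differs from compound 2 by vinyl in place of cyclohexyl on a saturated chain carbon bound to an oxygen on an unsaturated carbon. Within the data shown here, no measured step covers this kind of exchange: the one step known, from compound 1 to compound 2, concerns a different group on a different position. The expectation for compound 3 therefore rests on compound 2 sitting at the limit, with no evidence either way for the vinyl-for-cyclohexyl swap. Compound 3 is expected to stay near the limit, so the estimated step is a number no higher from compound 2 to compound 3 (the limit leaves the size open), not beyond the scatter. Compound 3 is thus estimated at 200000 nM, with a range from 80000 nM to 500000 nM in this assay.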

Compound 3, half-maximal cytotoxic concentration: > 200000 nM
Compound 3 gave a limit, no number; the forecaster's own chance of this, stated with the estimate: 60%; the middle value sits exactly at the limit.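

In this assay compound 3 gives > 200000 nM and this is a limit of the assay, not a number. The new information is that allyloxy, which has no ring, sits at the same limit as cyclohexylmethoxy, so the six-membered carbon ring of compound 2 is not needed for a result at the limit. Placing allyloxy instead of benzylamino on the double-bonded ring carbon gives an at least 2.1-fold higher number from compound 1 to compound 3 (0.33 log units; beyond the scatter) and thus repeats, with a much smaller group, the direction first seen with cyclohexylmethoxy; however, the step between compound 2 and compound 3 cannot be read, because both results are limits: the limit of > 200000 nM in this assay, at which 2 of the 3 values shown sit.

Any real difference between the cyclohexyl and vinyl ends therefore stays hidden, and it remains open whether an amine, a carboxylic acid or a longer chain at this place would stay at the limit or bring the result down to a readable number. On these data alone, it is also open whether the step away from compound 1 depends on the ring-bearing benzyl part or on the link to the core, which benzyloxy on the same double-bonded ring carbon would help to separate.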